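Swapping a Small Group for Phenyl on the Outer Ring

The source may report more compounds than this note shows. Statements on the series, on what has been measured and on what is new or still open speak of the compounds shown alone.

Compound 1 `COc1ccc(-n2cc(COc3ccc(/C=N/Nc4nc(-c5ccc(Br)cc5)cs4)cc3)nn2)cc1` gives 35600 nM
Compound 2 `COc1ccc(-c2csc(N/N=C/c3ccc(OCc4cn(-c5ccc(OC)cc5)nn4)cc3)n2)cc1` gives 39000 nM
Compound 3 `COc1ccc(-n2cc(COc3ccc(/C=N/Nc4nc(-c5ccc(C)cc5)cs4)cc3)nn2)cc1` gives 40300 nM

These values come from an ADME assay on THP-1 cells (Homo sapiens) for cytotoxicity; a lower number here means that less compound is tolerated, a higher number that more compound is tolerated. The three compounds differ in just one group, and compound 3 stands level with the other two within the scatter. On this measure compound 3 gives 40300 nM.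

Compound 4 `COc1ccc(-n2cc(COc3ccc(/C=N/Nc4nc(-c5ccc(-c6ccccc6)cc5)cs4)cc3)nn2)cc1` has not been measured yet. It is reached from compound 3 by one change, (phenyl in place of methyl on an aromatic carbon), which is phenyl in place of methyl on an aromatic carbon.

Going by the values given here, three measured steps bear on this position: a 1.1-fold higher number from compound 1 to compound 2 (0.04 log units; within the scatter) with methoxy in place of bromo, a 1.1-fold higher number from compound 1 to compound 3 (0.05 log units; within the scatter) with methyl in place of bromo, and a 1.0-fold higher number from compound 2 to compound 3 (0.01 log units; within the scatter) with methyl in place of methoxy. All three are small and stay within the scatter. So no step beyond the scatter is expected in this assay, in either direction. Still, none of the three measured groups brings a whole extra ring, so these steps are only a loose guide and the range is kept wide.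

The expected change is a 1.1-fold lower number from compound 3 to compound 4 (0.05 log units; within the scatter) in this estimate.

For compound 4 the estimated value is 36000 nM, with an expected range from 17000 nM to 75000 nM.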

Compound 4, half-maximal cytotoxic concentration: 35800 nM
Compound 4: middle estimate off by 1.0-fold (0.00 log units), on the high side; the measured number falls inside the stated range.
By their numbers in this assay, from the lowest: compounds 1, 4, 2 and 3 (each within the scatter of the next).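

In this assay the change from 4-methylphenyl to 4-phenylphenyl brings a whole extra six-membered aromatic ring to this position, yet the result is a 1.1-fold lower number from compound 3 to compound 4 (0.05 log units; within the scatter) and the picture stays the same against the other two groups. Measured against methoxy the step is a 1.1-fold lower number from compound 2 to compound 4 (0.04 log units; within the scatter) and measured against bromo it is a 1.0-fold higher number from compound 1 to compound 4 (0.00 log units; within the scatter) in the same way, so none of the groups compared here stands apart. Across these four compounds the position therefore takes a group as small as methyl or as large as phenyl without any step beyond the scatter, something the three smaller groups alone could not show, and nothing measured here explains this flat result.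

What remains open is whether the same flat picture would hold for an amine or a carboxylic acid at this place on the outer ring, since all four groups shown are of quite another kind. From the compounds shown here alone, it is also open whether a change elsewhere in the shared core, away from this position, would move the number in this assay beyond the scatter.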